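A few compounds are considered here, and "the series" means these few. Any claim that something is new, unique, unknown or untested is made for them only; others in the source may bear on it.

Measured so far in a functional assay on cells (leukaemia cell line, Homo sapiens) for inhibition, read by sulforhodamine B assay, with a stated time of 48 h; on this read-out higher numbers stand for lower toxicity in this test and lower numbers for higher toxicity in this test:
- Compound 1 `O=S(=O)(Nc1ccc(Cl)cc1Cl)c1ccc(-c2cnc(C3CC3)o2)cc1` gives > 100000 nM as a limit
- Compound 2 `O=S(=O)(Nc1ccc(F)cc1F)c1ccc(-c2cnc(C3CC3)o2)cc1` gives > 100000 nM as a limit
- Compound 3 `O=S(=O)(Nc1cc(Cl)ccc1Cl)c1ccc(-c2cnc(C3CC3)o2)cc1` gives > 100000 nM as a limit

Compound 3 stands at > 100000 nM as a limit and not a number. The series as a whole sits at one reading (the limit of > 100000 nM in this assay, at which 3 of the 3 values shown sit). Compound 4 `Cc1cc(F)cc(NS(=O)(=O)c2ccc(-c3cnc(C4CC4)o3)cc2)c1` carries 3-fluoro-5-methylphenyl in place of 2,5-dichlorophenyl on a sulfonamide nitrogen. The measured changes at that same place are a step that the two limits leave unreadable from compound 1 to compound 2 and a step that the two limits leave unreadable from compound 1 to compound 3 and also a step that the two limits leave unreadable from compound 2 to compound 3 as the third one. None of these has a readable size, so no number carries over, and all three compounds remain at the limit. No step beyond the scatter is expected in this assay in either direction. The expected step is a number no higher from compound 3 to compound 4 (the limit leaves the size open) as an estimate. Compound 4 is expected at 100000 nM with an estimated range from 40000 nM to 250000 nM and will most likely be reported as a limit again.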

Compound 4, concentration lethal to 50% of the cells: 78100 nM
Compound 4: middle estimate off by 1.3-fold (0.11 log units), on the high side; the measured number falls inside the stated range.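

Among the compounds shown, only compound 4 reads as a number and not a limit in this assay, so steps at the sulfonamide nitrogen become partly readable, while those among compound 1, compound 2 and compound 3 cannot be read. Placing 3-fluoro-5-methylphenyl on that nitrogen gives an at least 1.2-fold lower number from compound 3 to compound 4 (0.10 log units; that floor lies within the scatter), an at least 1.2-fold lower number from compound 2 to compound 4 (0.10 log units; that floor lies within the scatter) and an at least 1.2-fold lower number from compound 1 to compound 4 (0.10 log units; that floor lies within the scatter); each floor lies within the scatter, so no change beyond it is established. The series still stays close to a single reading: the limit of > 100000 nM in this assay, at which 3 of the 4 values shown sit.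

From the compounds shown here alone, the true size of these steps stays open, as the other three compounds carry only limits. Also open, going by these compounds, is how this assay would respond to an amine or a carboxylic acid on the phenyl group, or to a longer chain on the sulfonamide nitrogen.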